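A few compounds are considered here, and "the series" means these few. Any claim that something is new, unique, unknown or untested is made for them only; others in the source may bear on it.

Working notes on the ester series. All three measured compounds share one core and differ only in the ester group. Compound 1 `CCCc1nc(CC)c(C(=O)OCC(=O)c2ccccc2)n1Cc1ccc(-c2ccccc2S(=O)(=O)NC(=O)OCCC(C)C)cc1F` gives 2 nM in an assay on isolated protein for binding affinity to Type-2 angiotensin II receptor (Homo sapiens); on this read-out higher numbers stand for weaker inhibition and lower numbers for stronger inhibition. Compound 2 `CCCc1nc(CC)c(C(=O)OCc2ccccc2S(=O)(=O)c2ccccc2)n1Cc1ccc(-c2ccccc2S(=O)(=O)NC(=O)OCCC(C)C)cc1F` gives 5 nM in this assay. Compound 3 `CCCc1nc(CC)c(C(=O)OCCC[S+]([O-])c2ccccc2)n1Cc1ccc(-c2ccccc2S(=O)(=O)NC(=O)OCCC(C)C)cc1F` gives 1 nM in this assay, the lowest of the three numbers; against compound 1 the gap is within the scatter, against compound 2 it lies beyond it. Compound 4 `CCCc1nc(CC)c(C(=O)OCc2ccccc2-c2ccccc2)n1Cc1ccc(-c2ccccc2S(=O)(=O)NC(=O)OCCC(C)C)cc1F` has not been measured in this assay. It differs from compound 3 by a group of 12 heavy atoms (12 carbon; 2 six-membered aromatic rings of carbon only) in place of a group of 10 heavy atoms (8 carbon, 1 oxygen, 1 sulfur; one six-membered aromatic ring of carbon only), on a saturated chain carbon bound to an oxygen next to a carbonyl group. Going by the values given here, of the measured steps, only the one from compound 1 to compound 3 touches the same place: a 2.0-fold lower number from compound 1 to compound 3 (0.30 log units; within the scatter). That step stayed within the scatter, and compound 2 gives a number not far from those of compound 1 and compound 3, so exchanges at this place have so far moved the read-out little. A step of a 3.0-fold higher number from compound 3 to compound 4 (0.48 log units; beyond the scatter) is therefore expected, a modest loss at most. Compound 4 is estimated at 3 nM in this assay, with a range of 1 nM to 10 nM.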

Compound 4, half-maximal inhibitory concentration: 9 nM
The estimate for compound 4 lay 3.0-fold (0.48 log units) below the measured number, and the stated range covers the measured number.
By their numbers in this assay, from the lowest: compounds 3 and 1 (each within the scatter of the next); then compounds 2 and 4 (each within the scatter of the next).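

Going by these compounds alone, this position proves less permissive than the first three esters suggested: in this assay, 2-phenylphenyl gives the widest gap so far (a 9.0-fold higher number from compound 3 to compound 4 (0.95 log units; beyond the scatter)), and the step from the benzoyl ester also lies beyond the scatter (a 4.5-fold higher number from compound 1 to compound 4 (0.65 log units; beyond the scatter)). Phenyl in place of phenylsulfonyl on an aromatic carbon, by contrast, stays within the scatter (a 1.8-fold higher number from compound 2 to compound 4 (0.26 log units; within the scatter)), so at this level the read-out does not separate these two groups. Nothing available explains this result.

The step from compound 3 to compound 4 changes the ring count and removes both oxygen and sulfur at once, so their contributions cannot be separated. On these data alone, whether an ester carrying no aromatic ring, such as a plain longer chain, or one ending in an amine or a carboxylic acid would hold the lower numbers remains open.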